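Methyl on the amide aryl ring of compound 2

A few compounds are considered here, and "the series" means these few. Any claim that something is new, unique, unknown or untested is made for them only; others in the source may bear on it.

Measured so far:
compound 1, `O=C(Nc1ccccc1)c1cc2cnc(Nc3ccccc3)nc2n1C1CCCC1`, 14000 nM
compound 2, `O=C(Nc1ccccc1)c1cc2cnc(Nc3ccc(N4CCNCC4)cn3)nc2n1C1CCCC1`, 2800 nM

The read-out is a functional assay on MIA PaCa-2 cells (Homo sapiens) for inhibition, read by MTT assay; on this read-out higher numbers stand for weaker inhibition and lower numbers for stronger inhibition. Going by the values given here, compound 2 holds the lowest of the two numbers; its only neighbour is compound 1, which gives 14000 nM, a step of a 5.0-fold lower number from compound 1 to compound 2 (0.70 log units; beyond the scatter) on exchange of 5-(piperazin-1-yl)pyridin-2-yl for phenyl on a nitrogen on an aromatic ring.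

Compound 3, `Cc1ccccc1NC(=O)c1cc2cnc(Nc3ccc(N4CCNCC4)cn3)nc2n1C1CCCC1`, keeps that whole side of compound 2 and alters the phenylcarbamoyl end only: methyl in place of hydrogen on an aromatic carbon. Among the compounds with values here, the place is an aromatic carbon of a six-membered aromatic ring of carbon only, ortho to a large group, so the group enters at the opposite end of the molecule from the one change measured so far. Within the data shown here, the single step in hand, from compound 1 to compound 2, therefore gives no direct reading on a methyl at this position; it only shows that the series can move by a 5.0-fold lower number from compound 1 to compound 2 (0.70 log units; beyond the scatter) when the other end is changed. With nothing measured at the amide aryl ring, no step beyond the scatter is expected in this assay. Compound 3 is estimated at 2800 nM, range 900 nM to 8500 nM, a step of no change at the digits printed from compound 2 to compound 3 (within the scatter).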

Compound 3, half-maximal inhibitory concentration: 2500 nM
For compound 3 the middle estimate is 1.1-fold (0.05 log units) above the measured one; measured number inside the range.
By their numbers in this assay, from the lowest: compounds 3 and 2 (each within the scatter of the next); then compound 1.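

The (2-methylphenyl)carbamoyl end now has its first reading in this assay with a 1.1-fold lower number from compound 2 to compound 3 (0.05 log units; within the scatter) as the step, which lies within the scatter. Going by these compounds alone, the only earlier step, a 5.0-fold lower number from compound 1 to compound 2 (0.70 log units; beyond the scatter) at the opposite end of the molecule, gave no reading on the amide aryl ring; this one shows that methyl in place of hydrogen on an aromatic carbon, ortho to a large group, leaves the number within the scatter of the parent while the 5-(piperazin-1-yl)pyridin-2-yl side stays fixed. The added single carbon therefore marks this place as one where a small group can be carried in this series without a step beyond the scatter, though that rests on this one pair alone.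

The compounds shown leave open whether a larger or different group at this place, such as an ethyl chain, a methoxy group, a chlorine atom, an amine or a carboxylic acid, would move the number beyond the scatter. They also leave open how a methyl would read on the other carbons of the same ring. Nothing at hand bears on the reason for this reading.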